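The source may hold more compounds than are shown below. What is called first, only, known or untested is meant among the compounds shown, and "the series" means these compounds.

Notes on the series. Compound 1 `COc1ccc(C(=O)/C=C\Nc2ccc(-c3nc4cc(OC)c(OC)c(OC)c4s3)cc2C)cc1F` and compound 2 `COc1ccc(C(=O)/C=C\Nc2ccc(-c3nc4cc(OC)c(OC)c(OC)c4s3)cc2C)cc1[N+](=O)[O-]` share one core; compound 3 `COc1ccc2nc(-c3ccc(N/C=C\C(=O)c4ccc(OC)c([N+](=O)[O-])c4)cc3)sc2c1` and compound 4 `COc1ccc2nc(-c3ccc(N/C=C\C(=O)c4ccc(OC)c(F)c4)cc3)sc2c1` share another, and the difference between the two cores is not broken down here. In a functional assay on A549 cells (Homo sapiens) for antiproliferative activity, read by sulforhodamine B assay, with a stated time of 48 h (on this read-out higher numbers stand for weaker inhibition and lower numbers for stronger inhibition), compound 1 gives 1690 nM. In this assay compound 2 gives 9100 nM. The change from compound 2 to compound 1 is fluoro in place of nitro on an aromatic carbon, and it brought a 5.4-fold lower number from compound 2 to compound 1 (0.73 log units; beyond the scatter). In this assay compound 3 gives 13600 nM; the gap to compound 2 is within the scatter, the gap to compound 1 beyond it. The change from compound 3 to compound 4 is fluoro in place of nitro on an aromatic carbon, the same change as before, at a place described in the same words. With a single earlier example to rest on, the expected step for compound 4 is set a little short of that earlier one, so the estimated step is a 4.5-fold lower number from compound 3 to compound 4 (0.66 log units; beyond the scatter), resting on compound 3 at 13600 nM and on the step of a 5.4-fold lower number from compound 2 to compound 1 (0.73 log units; beyond the scatter). Compound 4 is therefore expected at 3000 nM, with a likely range from 1200 nM to 8000 nM.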

Compound 4, half-maximal inhibitory concentration: 900 nM
The estimate for compound 4 lay 3.3-fold (0.52 log units) above the measured number; the measured number lies below the stated range.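

In this assay, the change from 4-methoxy-3-nitrophenyl to 3-fluoro-4-methoxyphenyl brought a 15-fold lower number from compound 3 to compound 4 (1.18 log units; beyond the scatter), so on this second core the step runs in the same direction as on the first. The direction carried over, but the size did not, and a step measured on one core gives only a rough guide to the step on the other: the same change on two cores in this assay, a 5.4-fold lower number (0.73 log units; beyond the scatter) from compound 2 to compound 1 and a 15-fold lower number (1.18 log units; beyond the scatter) from compound 3 to compound 4, 2.8-fold (0.45 log units) apart, beyond the scatter of two such steps These two pairs do not show why the size differs, and as the difference between the two cores is not broken down, the gap cannot be assigned to any part of it; nor do two cores establish a rule for a third.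

Going by these compounds, it remains open which part of the core sets the size of the step, and whether the same gap would appear with the nitro group replaced by an amine, a nitrile or a chloro group at the same place. Also open, on these data alone, is whether the step would keep its direction on these two cores in any read-out other than this assay.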